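Shortening and saturating the chain on the amidine carbon

This account rests on a few compounds, and the source may have more. Where it says the series, first, only, none or still open, it means among the compounds named here.

Measured compounds: compound 1 `C=CCC(=N)NCCC[C@H](N)C(=O)O` gives 2000 nM in an assay on isolated protein for inhibition of N(G),N(G)-dimethylarginine dimethylaminohydrolase 1 (Homo sapiens); a higher number here means a weaker inhibitor, a lower number a stronger inhibitor; compound 2 `C/C=C/CC(=N)NCCC[C@H](N)C(=O)O` gives 36000 nM in this assay.

Going by the values given here, on these two numbers compound 2 stands highest; its nearest neighbour is compound 1, and the single measured step of an 18-fold higher number from compound 1 to compound 2 (1.26 log units; beyond the scatter) is large. Compound 3 `CCCC(=N)NCCC[C@H](N)C(=O)O` differs from compound 2 by ethyl in place of prop-1-en-1-yl on a saturated chain carbon bound to a carbon with a double bond to nitrogen. The step from compound 1 to compound 2 bears on this change only in part, since it added a carbon to the double bond rather than removing the double bond. A partial reversal toward compound 1 is expected, so compound 3 is estimated at 8000 nM (2000 nM to 30000 nM), a step of a 4.5-fold lower number from compound 2 to compound 3 (0.65 log units; beyond the scatter).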

Compound 3, inhibition constant: 32000 nM
For compound 3 the middle estimate is 4.0-fold (0.60 log units) below the measured one; the whole stated range lies below it.
By their numbers in this assay, from the lowest: compound 1; then compounds 3 and 2 (each within the scatter of the next).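

In this assay, ethyl and prop-1-en-1-yl cannot be told apart at this position, with a 1.1-fold lower number from compound 2 to compound 3 (0.05 log units; within the scatter). Vinyl alone stands apart, with a 16-fold higher number from compound 1 to compound 3 (1.20 log units; beyond the scatter), so among these three compounds the lower number goes with vinyl itself and not with any double bond, since compound 2 also carries one. Nothing available explains this difference. Open, going by these compounds, is how an ethynyl group or a methyl group would compare with vinyl on this saturated chain carbon.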